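Changing the Ring on the Sulfur: Compound 2 to Compound 3

The compounds below may be only part of what the source reports. "The series", "measured", "known", "first", "only" and "open" are said of these compounds alone.

Compound 1 `Nc1ccccc1NC(=O)/C=C/c1ccc(CSc2ccc(Cl)cc2)cc1` and compound 2 `Nc1ccccc1NC(=O)/C=C/c1ccc(CSc2cccc(F)c2)cc1` share one core and differ only in the ring carried on the sulfur. In a functional assay on SMMC-7721 cells (Homo sapiens) for inhibition, read by CCK-8 assay, with a stated time of 72 h, tested at 8 uM (on this read-out higher numbers stand for more inhibition of growth at the one concentration tested and lower numbers for less inhibition of growth), compound 1 gives 16.5%, and compound 2 gives 8.25%. Among the measured compounds shown here, the step of a number 8.3 percentage points lower from compound 1 to compound 2 (within the scatter) lies within the scatter, so the two numbers cannot be told apart; compound 2 therefore stands as one of two values that are indistinguishable, with compound 1 as its only neighbour.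

Compound 3 `CC(C)(C)c1ccc(SCc2ccc(/C=C/C(=O)Nc3ccccc3N)cc2)cc1` has not yet been measured. It differs from compound 2 in one place: 4-(tert-butyl)phenyl in place of 3-fluorophenyl on a sulfur. For the measured compounds named here, the only measured step touching the ring on the sulfur is a number 8.3 percentage points lower from compound 1 to compound 2 (within the scatter), which stayed within the scatter, and no measured compound carries a 4-(tert-butyl)phenyl group. On this basis the step of a number 3.8 percentage points higher from compound 2 to compound 3 (within the scatter) is expected to stay within the scatter. Compound 3 is estimated to give 12%, in a range from 0% to 30%.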

Compound 3, percent growth inhibition at one concentration: 23.6%
Estimate against measurement, compound 3: 11.6 percentage points below, and the stated range covers the measured number.
By their numbers in this assay, from the lowest: compounds 2, 1 and 3 (each within the scatter of the next, the first and the last beyond it).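

Among the compounds shown here, replacing 3-fluorophenyl on the sulfur with 4-(tert-butyl)phenyl gives a number 15.4 percentage points higher from compound 2 to compound 3 (beyond the scatter) in this assay, the first step at this position to clear the usual scatter, so the ring carried on the sulfur can shift this read-out. Tert-butyl in place of chloro on an aromatic carbon gives a number 7.1 percentage points higher from compound 1 to compound 3 (within the scatter), so compound 1 and compound 3 cannot be told apart, and only compound 2 and compound 3 are separated. No measurement at hand gives a reason for this difference.

The compounds shown leave open how an amine, a carboxylic acid or a longer chain on this ring would read in this assay. They also leave open whether an unsubstituted phenyl on the sulfur would sit with compound 2 or with compound 3.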